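Chain-linked aryl groups on the shared core

The compounds below may be only part of what the source reports. "The series", "measured", "known", "first", "only" and "open" are said of these compounds alone.

Among the measured compounds shown here, compound 3 `CCn1c(=O)[nH]c2ccc(OCCCOc3ccccc3)cc21` is one of three compounds measured in an assay on cells for inhibition of Amine oxidase [flavin-containing] B (Homo sapiens), read by fluorescence, with stated times of 30 min and 15 min, tested at 1 uM (a lower number here means less inhibition, a higher number more inhibition at the concentration tested (going by the name of the read-out)), where compound 3 gives 11.3%. Compound 1 `CCn1c(=O)[nH]c2ccc(OCCOc3ccc(Cl)cc3)cc21` gives 7.24% in this assay, a number within the scatter of compound 3, so the two cannot be told apart on these data. Compound 2 `O=C1Nc2ccc(OCc3ccc(Cl)c(Cl)c3)cc2C1=O`, built on a different core, gives 95.7% in this assay, far beyond the scatter of compound 3. Compound 3 therefore sits with compound 1 among the low numbers, while compound 2 lies well above it.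

Compound 4 `CCn1c(=O)[nH]c2ccc(OCCCc3ccccc3)cc21` has not yet been measured. It differs from compound 3 in one place: phenyl in place of phenoxy on a saturated chain carbon, three bonds along the chain from an oxygen on an aromatic ring. Core and chain are otherwise unchanged. For the measured compounds named here, no step between two measured compounds tracks this exchange, so nothing measured guides its size directly. Both compounds that share the core of compound 3, compound 1 with 7.24% and compound 3 with 11.3%, give low numbers in this assay despite differing in chain and aryl group, which makes a large move unlikely. The step of a number 0.7 percentage points higher from compound 3 to compound 4 (within the scatter) is expected to stay within the scatter, with no clear direction. Compound 4 is estimated at 12%, with a range from 0% to 30%.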

Compound 4, a percentage reported as inhibition, at one concentration (the size of the read-out at that concentration, not a potency): 4.56%
Estimate against measurement, compound 4: 7.4 percentage points above; the measured number falls inside the stated range.
By their numbers in this assay, from the lowest: compounds 4, 1 and 3 (each within the scatter of the next); then compound 2.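

In this assay, among the compounds shown here, phenyl in place of phenoxy on a saturated chain carbon, three bonds along the chain from an oxygen on an aromatic ring, gives a number 6.7 percentage points lower from compound 3 to compound 4 (within the scatter), the first reading of a single change at this position. At this place, the oxygen of phenoxy can therefore go without the read-out moving beyond the scatter, and the aromatic ring at the chain end stays in both compounds, so this pair gives no sign that the oxygen matters for the number at the concentration tested. No measurement on hand bears on why the step has this size.

On these data alone, whether an amine or a carboxylic acid in place of phenyl, or a longer chain carrying the same phenyl, would lift the number on the shared core remains open. On a different core, compound 2 gives 95.7% in this assay, but it differs from the low-number compounds in more than one place, so the gap cannot be assigned to the core, the chain or the aryl group.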